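Extending the chain on a charged core: expected tolerance

The source may report more compounds than this note shows. Statements on the series, on what has been measured and on what is new or still open speak of the compounds shown alone.

In an ADME assay on CEM174 cells (Homo sapiens) for cytotoxicity (a higher number here means that more compound is tolerated, a lower number that less compound is tolerated), compound 1, `CCN(CC)c1nc(C)c2[nH]c(SCC(=O)NCCNC(=N)N)nc2n1`, gives > 100 uM, which is a limit of the assay rather than a number. Compound 2, `CCN(CC)c1nc(C)c2[nH]c(SCC(=O)NCCCNC(=N)N)nc2n1`, carries a group of 5 heavy atoms (2 carbon, 3 nitrogen; no ring) in place of a group of 4 heavy atoms (1 carbon, 3 nitrogen; no ring), on a saturated chain carbon, two bonds along the chain from an amide-type nitrogen. In this assay compound 2 gives > 100 uM, again a limit. The measured step is therefore a step that the two limits leave unreadable from compound 1 to compound 2. Compound 3, `CCN(CC)CC[n+]1c(SCC(=O)NCCNC(=N)N)[nH]c2c(C)nc(N(CC)CC)nc21`, has a different core from compound 1; the difference between the two cores is not broken down here. In this assay compound 3 gives > 100 uM, also a limit. Compound 4, `CCN(CC)CC[n+]1c(SCC(=O)NCCCNC(=N)N)[nH]c2c(C)nc(N(CC)CC)nc21`, is not yet measured; it differs from compound 3 by a group of 5 heavy atoms (2 carbon, 3 nitrogen; no ring) in place of a group of 4 heavy atoms (1 carbon, 3 nitrogen; no ring), on a saturated chain carbon, two bonds along the chain from an amide-type nitrogen, the same change as that from compound 1 to compound 2, at a place described in the same words. The expectation for compound 4 rests on (the limit of > 100 uM in this assay, at which 3 of the 3 values shown sit); because of the limit of > 100 uM in this assay, at which 3 of the 3 values shown sit, compound 4 is expected to show no toxicity below that limit either. The expected step is a step that the limit leaves unreadable from compound 3 to compound 4. The estimate for compound 4 is 150 uM, with a range from 80 uM to 300 uM.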

Compound 4, half-maximal toxic concentration: > 100 uM
Compound 4: only a limit was reported; the forecaster's own chance of this, stated with the estimate: 85%; the middle value is on the limit's open side.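

Compound 3 and compound 4 each gave only a limit of the assay rather than a number, so no step can be read between them, just as none can be read between compound 1 and compound 2. The compounds shown leave open the concentration at which toxicity would begin for any of them, and whether the longer chain shifts it: the limit of > 100 uM in this assay, at which 4 of the 4 values shown sit.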